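Compound 3 and the Way Back from a Limit

This account rests on a few compounds, and the source may have more. Where it says the series, first, only, none or still open, it means among the compounds named here.

In a functional assay on MIA PaCa-2 cells (Homo sapiens) for inhibition, read by MTT assay, with a stated time of 72 h (on this read-out higher numbers stand for weaker inhibition and lower numbers for stronger inhibition), compound 1 (`COc1cc(NC(C)CCCNC(=O)Nc2ccc(Br)cc2)c2ncccc2c1`) gives 23000 nM. Compound 2 (`COc1cc(NC(C)CCCNC(=O)NNC(=O)Nc2ccc(Cl)cc2)c2ncccc2c1`) stands at >= 250000 nM, which is a limit of the assay and not a number. Going by the values given here, the one measured step, an at least 10-fold higher number from compound 1 to compound 2 (1.03 log units; beyond the scatter), is large and beyond the scatter, and it puts ((4-chlorophenyl)carbamoyl)amino in place of 4-bromophenyl on an amide-type nitrogen. Compound 3 (`COc1cc(NC(C)CCCNC(=O)Nc2cccc(O)c2)c2ncccc2c1`) reverses that kind of change: 3-hydroxyphenyl in place of ((4-chlorophenyl)carbamoyl)amino on an amide-type nitrogen. It carries 3-hydroxyphenyl in place of ((4-chlorophenyl)carbamoyl)amino, so a large step towards stronger inhibition is expected in this assay, judging from an at least 10-fold higher number from compound 1 to compound 2 (1.03 log units; beyond the scatter) read backwards. Among the compounds with values here, no measured step shows how 3-hydroxyphenyl compares with 4-bromophenyl, so the range stays wide. The expected size is an at least 8.3-fold lower number from compound 2 to compound 3 (0.92 log units; beyond the scatter). Compound 3 is estimated at 30000 nM, within an expected range of 10000 nM to 90000 nM.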

Compound 3, half-maximal inhibitory concentration: 46000 nM
Compound 3: the middle estimate sits 1.5-fold (0.19 log units) below what was measured; measured number inside the range.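

In this assay, going by these compounds alone, putting 3-hydroxyphenyl on the amide-type nitrogen of compound 2 in place of ((4-chlorophenyl)carbamoyl)amino gives an at least 5.4-fold lower number from compound 2 to compound 3 (0.73 log units; beyond the scatter), so 4-bromophenyl is not the only group at this place that avoids the loss seen with compound 2. Exchanging 4-bromophenyl for 3-hydroxyphenyl gives a 2.0-fold higher number from compound 1 to compound 3 (0.30 log units; within the scatter), and so the two groups cannot be told apart in this assay. The value of compound 2 is a limit of the assay and not a number, so the size of the first step is a bound only: the limit of >= 250000 nM in this assay, at which 1 of the 3 values shown sits.

Going by these compounds, what an unsubstituted phenyl or a 4-hydroxyphenyl would give on this nitrogen remains open. So does the effect of a benzyl group, or of a cyclohexyl group in place of the ring.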